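This account rests on a few compounds, and the source may have more. Where it says the series, first, only, none or still open, it means among the compounds named here.

Compound 1 `CCCN(CCC)Cc1ccc(Cl)c(-c2ccccc2OC)c1`: > 10000 nM
Compound 2 `CCNCc1ccc(Cl)c(-c2ccccc2OC)c1`: 1400 nM
Compound 3 `CCCCNCc1ccc(Cl)c(-c2ccccc2OC)c1`: 240 nM

In an assay on isolated protein for binding affinity to 5-hydroxytryptamine receptor 6 (Homo sapiens) (on this read-out higher numbers stand for weaker inhibition and lower numbers for stronger inhibition), compound 1 reaches only a limit of the assay, > 10000 nM, so its actual number is not known. That limit, (the limit of > 10000 nM in this assay, at which 1 of the 3 values shown sits), is the starting point of the step to compound 4. Compound 4 `CCN(CC)Cc1ccc(Cl)c(-c2ccccc2OC)c1` differs from compound 1 in one place: diethylamino in place of dipropylamino on a saturated chain carbon bound to an aromatic carbon. Two measured steps also leave the dipropylamino group: an at least 7.1-fold lower number from compound 1 to compound 2 (0.85 log units; beyond the scatter) and an at least 41-fold lower number from compound 1 to compound 3 (1.61 log units; beyond the scatter). Between those two products, a 5.8-fold lower number from compound 2 to compound 3 (0.77 log units; beyond the scatter). Compound 4 still carries two chains on its nitrogen, as compound 1 does, and only shortens them, so it sits closer to compound 1 than either of the measured products; a gain over compound 1 is expected, but a smaller one than either measured step, and a limit remains possible. The step from compound 1 to compound 4 is therefore expected as an at least 2.0-fold lower number from compound 1 to compound 4 (0.30 log units; that floor lies within the scatter). For compound 4 in this assay the expected value is 5000 nM, with a range from 1000 nM to 20000 nM.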

Compound 4, inhibition constant: 2000 nM
Estimate against measurement, compound 4: 2.5-fold (0.40 log units) above; low and high end bracket the measured number.
By their numbers in this assay, from the lowest: compound 3; then compounds 2 and 4 (each within the scatter of the next). At a limit, above all of these: compound 1.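

In this assay, a second chain on the nitrogen does not by itself take the read-out to a limit, as diethylamino in place of dipropylamino gives an at least 5.0-fold lower number from compound 1 to compound 4 (0.69 log units; beyond the scatter). The ethyl on the amine nitrogen leaves no step beyond the scatter, with a 1.4-fold higher number from compound 2 to compound 4 (0.15 log units; within the scatter), while diethylamino in place of butylamino gives an 8.3-fold higher number from compound 3 to compound 4 (0.92 log units; beyond the scatter), so among these compounds the single butyl chain remains the best-reading amine substituent. The size of the first step remains only a floor, since its starting point is a limit: the limit of > 10000 nM in this assay, at which 1 of the 4 values shown sits.

Open, on these data alone, is whether propylamino or a longer chain such as pentylamino on the same carbon would extend the trend from ethylamino to butylamino. Also open, as far as these compounds go, is how a ring amine such as pyrrolidine or piperidine would read there.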